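Series notes: stripping the ethyl from compound 2

This account rests on a few compounds, and the source may have more. Where it says the series, first, only, none or still open, it means among the compounds named here.

Three compounds have been run in a functional assay for inhibition, with Homo sapiens as the target (on this read-out higher numbers stand for weaker inhibition and lower numbers for stronger inhibition), so far, and none yields a number. Compound 1 `CCCc1nc(C)c2c(C)nn(CC(=O)O)c(=O)n12` returns only the limit > 48000 nM in this assay. Compound 2 `C=CCn1ncc2c(CC)ncn2c1=O` likewise stops at the limit > 48000 nM in this assay. Compound 3 `CSc1nncc2c(C)nc(C(C)C)n12` also sits at the limit > 48000 nM in this assay. Compound 2 therefore stands exactly where every measured value stands, namely at the limit of > 48000 nM in this assay, at which 3 of the 3 values shown sit, and no ordering among the three is possible. Compound 4 `C=CCn1ncc2cncn2c1=O` is the next member; it differs from compound 2 by hydrogen in place of ethyl on an aromatic carbon. For the measured compounds named here, with every value at the limit there is no measured step to lean on, and no change beyond the scatter is expected in this assay. Compound 4 is expected to give about 60000 nM in this assay, within 20000 nM to 200000 nM, most probably reported again only as a limit. The expected step from compound 2 to compound 4 is a step that the limit leaves unreadable from compound 2 to compound 4, that is, none beyond the scatter.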

Compound 4, half-maximal inhibitory concentration: > 48000 nM
Compound 4: a limit, no number; the forecaster's own chance of this, stated with the estimate: 85%; the middle value is on the limit's open side.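

Compound 2 and compound 4 both stop at a limit, so no step can be read between them: the limit of > 48000 nM in this assay, at which 4 of the 4 values shown sit. The compounds shown leave open whether ethyl or hydrogen at this place makes any difference in this assay.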